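Ring Opening at the Aromatic Carbon: Compound 2 to Compound 3

This account rests on a few compounds, and the source may have more. Where it says the series, first, only, none or still open, it means among the compounds named here.

Two compounds have been measured in an assay on CHO cells for antagonist activity at transient receptor potential cation channel subfamily V member 1 (Homo sapiens), read by FLIPR and calcium flux; on this read-out higher numbers stand for weaker inhibition and lower numbers for stronger inhibition:

compound 1, `CC(C(=O)NCc1ccc(C(F)(F)F)nc1C1CCC(C)(C)CC1)c1ccc(NS(C)(=O)=O)c(F)c1`: 0.4 nM
compound 2, `CC(C(=O)NCc1ccc(C(F)(F)F)nc1C1=CCCCC1)c1ccc(NS(C)(=O)=O)c(F)c1`: 0.7 nM

Compound 2 carries the higher of the two numbers, but the step of a 1.8-fold higher number from compound 1 to compound 2 (0.24 log units; within the scatter) is within the scatter, so the two compounds cannot be told apart on these data. Compound 3, `CC(C)=Cc1nc(C(F)(F)F)ccc1CNC(=O)C(C)c1ccc(NS(C)(=O)=O)c(F)c1`, differs from compound 2 in one place: 2-methylprop-1-en-1-yl in place of cyclohex-1-en-1-yl on an aromatic carbon. Within the data shown here, the only measured step that touches this position is the one from compound 1 to compound 2, and it was small; no measured step replaces the ring with an open chain, so the effect of losing the ring is unknown here. Compound 3 is therefore expected to land near compound 2, with some allowance for a weaker number, a step of a 2.1-fold higher number from compound 2 to compound 3 (0.33 log units; beyond the scatter). The estimate for compound 3 in this assay is 1.5 nM, within 0.5 nM to 5 nM.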

Compound 3, inhibition constant: 11.5 nM
Compound 3: middle estimate off by 7.7-fold (0.88 log units), on the low side; the measured number lies above the stated range.
By their numbers in this assay, from the lowest: compounds 1 and 2 (each within the scatter of the next); then compound 3.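

Opening the ring is the change that moves this position: in this assay, 2-methylprop-1-en-1-yl in place of cyclohex-1-en-1-yl gives a 16-fold higher number from compound 2 to compound 3 (1.22 log units; beyond the scatter), whereas replacing one ring with another had stayed within the scatter (a 1.8-fold higher number from compound 1 to compound 2 (0.24 log units; within the scatter)). The same open chain in place of 4,4-dimethylcyclohexyl gives a 29-fold higher number from compound 1 to compound 3 (1.46 log units; beyond the scatter), and since compound 2 and compound 3 each carry one double bond outside aromatic rings, having that double bond does not by itself keep the number low. No evidence at hand explains the rise.

As far as these compounds go, whether a cyclopentyl or phenyl ring here would stay close to compound 2 or fall nearer to compound 3 remains open. So does whether a saturated 2-methylpropyl chain would differ from 2-methylprop-1-en-1-yl.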